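A few compounds are considered here, and "the series" means these few. Any claim that something is new, unique, unknown or untested is made for them only; others in the source may bear on it.

Measured compounds:

Compound 1 `CC(C)(C)[C@H]1CC[C@]2(CC1)N=C(c1ccc(C(F)(F)F)cc1)C(=O)N2Cc1ccc(C(=O)NCCC(=O)O)cc1`, in a functional assay on CHO cells for antagonist activity at Glucagon receptor (Homo sapiens), read by cAMP accumulation, with stated times of 30 min and 45 min; on this read-out higher numbers stand for weaker inhibition and lower numbers for stronger inhibition: 800 nM
Compound 2 `CC(C)(C)CC[C@H](c1ccc(C(=O)NCc2nn[nH]n2)cc1)N1C(=O)C(c2cccc(C(F)(F)F)c2)=N[C@]12CC[C@@H](C(C)(C)C)CC2`, in this assay: 180 nM
Compound 3 `CC(C)CC[C@H](c1ccc(C(=O)NCc2nn[nH]n2)cc1)N1C(=O)C(c2cc(Cl)cc(Cl)c2)=N[C@]12CC[C@@H](C(C)(C)C)CC2`, in this assay: 150 nM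

Among these three numbers compound 2 stands second highest. Its nearest neighbour is compound 3, whose number is within the usual scatter of that of compound 2, so the two cannot be put in order. Its furthest neighbour is compound 1, whose number lies beyond the scatter above that of compound 2, so compound 2 is the stronger inhibitor of that pair. Compound 3 differs from compound 2 in more than one place, so none of the pairs measured here isolates a single change.

Compound 4 `CC(C)(C)CC[C@H](c1ccc(C(=O)NCc2nn[nH]n2)cc1)N1C(=O)C(c2cnccc2C(F)(F)F)=N[C@]12CC[C@@H](C(C)(C)C)CC2` differs from compound 2 in one place: 4-(trifluoromethyl)pyridin-3-yl in place of 3-(trifluoromethyl)phenyl on a carbon with a double bond to nitrogen. Within the data shown here, no measured pair shows the effect of putting a ring nitrogen into that aromatic group, so the expectation rests on the measured range alone. It is estimated that the step from compound 2 to compound 4 in this assay will stay within the scatter, a 1.4-fold higher number from compound 2 to compound 4 (0.14 log units; within the scatter), with a slightly higher number somewhat more likely than a lower one. Compound 4 is therefore expected to give about 250 nM in this assay, between 100 nM and 700 nM.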

Compound 4, half-maximal inhibitory concentration: 1200 nM
Estimate against measurement, compound 4: 4.8-fold (0.68 log units) below, and the stated range ends below it.
By their numbers in this assay, from the lowest: compounds 3 and 2 (each within the scatter of the next); then compounds 1 and 4 (each within the scatter of the next).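

In this assay, replacing 3-(trifluoromethyl)phenyl with 4-(trifluoromethyl)pyridin-3-yl on the carbon with a double bond to nitrogen gives a 6.7-fold higher number from compound 2 to compound 4 (0.82 log units; beyond the scatter). This is the first change in a single place among the compounds shown, and it establishes that the read-out at this position responds to which aromatic group is attached, with the weaker inhibition on the pyridine side. The two groups have the same count of heavy atoms, and they differ in one ring nitrogen, one hydrogen-bond acceptor against none, and the numbering of the trifluoromethyl group, but nothing measured here explains the loss.

This single step cannot separate the ring nitrogen from the different placement of the trifluoromethyl group, and a 2-(trifluoromethyl)phenyl group at this position would be needed to tell the two apart. As far as these compounds go, it also remains open whether a pyridine ring carrying the trifluoromethyl group at another ring carbon, or one carrying a chlorine or a methoxy group in its place, would behave in the same way.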